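The source may report more compounds than this note shows. Statements on the series, on what has been measured and on what is new or still open speak of the compounds shown alone.

Measured compounds in a functional assay on DU-145 cells (Homo sapiens) for antiproliferative activity, read by MTT assay, with a stated time of 72 h; a lower number here means a stronger inhibitor, a higher number a weaker inhibitor:
compound 1, `COc1ccccc1/C=C/C(=O)c1ccc(OCC(=O)N[C@H]2CCOC2=O)cc1`, 10100 nM
compound 2, `O=C(COc1ccc(C(=O)/C=C/c2ccccc2)cc1)N[C@H]1CCOC1=O`, 48300 nM
Not yet measured: compound 3, `O=C(COc1ccc(C(=O)/C=C/c2cccc([N+](=O)[O-])c2)cc1)N[C@H]1CCOC1=O`

Going by the values given here, compound 2 holds the highest of the two numbers in this assay; its only neighbour is compound 1, which gives 10100 nM. Among the compounds with values here, the single step between them, a 4.8-fold higher number from compound 1 to compound 2 (0.68 log units; beyond the scatter), is the only measured step, and it concerns a methoxy group leaving an aromatic carbon.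

The step to compound 3 is a different one: nitro in place of hydrogen on an aromatic carbon. Within the data shown here, no measured step involves a nitro group, and the one step that exists changes a different group at a different place on the same ring. It shows only that the bare phenyl of compound 2 sits at the weak end of what has been seen, so a substituent entering that ring is more likely to lower the number than to raise it, without any firm size to lean on.

For compound 3 the expected step is therefore a 1.9-fold lower number from compound 2 to compound 3 (0.29 log units; within the scatter), a modest lowering carrying wide uncertainty. The estimate for compound 3 in this assay is 25000 nM, expected between 8000 nM and 80000 nM.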

Compound 3, half-maximal inhibitory concentration: 41800 nM
For compound 3 the middle estimate is 1.7-fold (0.22 log units) below the measured one; low and high end bracket the measured number.
By their numbers in this assay, from the lowest: compound 1; then compounds 3 and 2 (each within the scatter of the next).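

In this assay, 3-nitrophenyl in place of phenyl gives a 1.2-fold lower number from compound 2 to compound 3 (0.06 log units; within the scatter), so nitro on an aromatic carbon, meta to a large group, leaves the number indistinguishable from that of the unsubstituted ring. Replacing the 2-methoxyphenyl with the 3-nitrophenyl gives a 4.1-fold higher number from compound 1 to compound 3 (0.62 log units; beyond the scatter), which leaves compound 1 as the only one of the three set apart by a step beyond the scatter and shows that a substituent on this ring does not by itself lower the number. No measurement bearing on the reason for either step is available.

Since compound 1 and compound 3 differ in both the group and its place on the ring, the series does not separate the contribution of methoxy from that of its location. As far as these compounds go, how an amine or a carboxylic acid on this ring would read in this assay remains open, as does whether any other group at either location can match or go beyond the number of compound 1.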